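A hydroxyphenyl variant in a weakly cytotoxic series

The source may hold more compounds than are shown below. What is called first, only, known or untested is meant among the compounds shown, and "the series" means these compounds.

Compound 3 `Fc1cccc(-c2nc(Nc3cccc(Cl)c3)c3cc(F)ccc3n2)c1` is measured in a functional assay on HT29-AK cells (Homo sapiens) for cytotoxicity, read by MTT assay, with a stated time of 48 h (a higher number here means a weaker inhibitor, a lower number a stronger inhibitor), and compound 3 reaches only the limit > 50000 nM there. Compound 1 `COc1ccccc1Nc1nc(-c2cccc(F)c2)nc2ccc(F)cc12` also sits at the limit > 50000 nM in this assay. Compound 2 `Fc1cccc(-c2nc(Nc3ccc(Cl)cc3)c3cc(F)ccc3n2)c1` gives 40300 nM in this assay. The step of an at least 1.2-fold higher number from compound 2 to compound 3 (0.09 log units; that floor lies within the scatter) has a floor inside the scatter, the step of an at least 1.2-fold lower number from compound 1 to compound 2 (0.09 log units; that floor lies within the scatter) likewise, and the step that the two limits leave unreadable from compound 1 to compound 3 cannot be read at all. Compound 4 `Oc1ccccc1Nc1nc(-c2cccc(F)c2)nc2ccc(F)cc12` carries the change (2-hydroxyphenyl in place of 3-chlorophenyl on a nitrogen on an aromatic ring). Given (the limit of > 50000 nM in this assay, at which 2 of the 3 values shown sit), no measured step reached beyond the scatter, so compound 4 is expected to show a step of a number no higher from compound 3 to compound 4 (the limit leaves the size open) in this assay. For compound 4 the estimate is 50000 nM, ranging from 20000 nM to 120000 nM.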

Compound 4, half-maximal inhibitory concentration: > 50000 nM
Compound 4: only a limit was reported; the forecaster's own chance of this, stated with the estimate: 65%; the middle value lies on the limit itself.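

Placing 2-hydroxyphenyl on the nitrogen, with the hydrogen-bond donor and acceptor that 3-chlorophenyl lacks, does not bring compound 4 off the limit in this assay. The steps to compound 4 from compound 1 and from compound 3 cannot be read, as both ends of each are limits. The only readable new step is an at least 1.2-fold higher number from compound 2 to compound 4 (0.09 log units; that floor lies within the scatter), and the series stays largely at one ceiling: the limit of > 50000 nM in this assay, at which 3 of the 4 values shown sit.

On these data alone, whether an aminophenyl or a carboxyphenyl group on this nitrogen, or a longer chain in place of the methyl on the oxygen of compound 1, would give a value clear of that limit remains open. As far as these compounds go, how far compound 1, compound 3 and compound 4 lie beyond it also remains open.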